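The compounds below may be only part of what the source reports. "The series", "measured", "known", "first", "only" and "open" are said of these compounds alone.

Measured compounds:
compound 1 `CCCCCCCCCCCC(=O)OC[C@H](CSC[C@@H](N)C(=O)NCCCC(C)(C)CO)OC(=O)CCCCCCCCCCC` with 30700 nM
compound 2 `CCCCCCCCCCCC(=O)OC[C@H](CSC[C@@H](N)C(=O)NC(C)CCc1ccccc1)OC(=O)CCCCCCCCCCC` with 160 nM
compound 3 `CCCCCCCCCCCC(=O)OC[C@H](CSC[C@@H](N)C(=O)N[C@@H](CO)C(=O)NCCOCCOCCOCCC(=O)O)OC(=O)CCCCCCCCCCC` with 4940 nM

In an assay on HEK293 cells for agonist activity at Toll-like receptor 2 (Homo sapiens) (a higher number here means that more compound is needed for the effect, a lower number that less compound is needed), compound 2 stands lowest of the three; compound 3 is nearest at a gap beyond the scatter, and compound 1 furthest, also beyond the scatter. Compound 4 `CCCCCCCCCCCC(=O)OC[C@H](CSC[C@@H](N)C(=O)NCCN)OC(=O)CCCCCCCCCCC` is not yet measured. It differs from compound 2 in one place: 2-aminoethyl in place of 1-methyl-3-phenylpropyl on an amide-type nitrogen. The step that bears most directly on this is a 190-fold lower number from compound 1 to compound 2 (2.28 log units; beyond the scatter), where a group with one hydrogen-bond donor and one acceptor gave way to the 1-methyl-3-phenylpropyl group on the same amide-type nitrogen; compound 4 runs that change back toward a group with one donor and one acceptor, though a much shorter one. Compound 3, which also carries donors and acceptors on the amide side, sits well above compound 2. The expectation for compound 4 is therefore a clearly higher number in this assay, of roughly the size a 50-fold higher number from compound 2 to compound 4 (1.70 log units; beyond the scatter), and the estimate for compound 4 is 8000 nM with a range from 1500 nM to 40000 nM.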

Compound 4, half-maximal effective concentration: 5240 nM
Beside the measured number, compound 4's estimate is 1.5-fold (0.18 log units) above it, and the stated range covers the measured number.
By their numbers in this assay, from the lowest: compound 2; then compounds 3 and 4 (each within the scatter of the next); then compound 1.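

In this assay, replacing 1-methyl-3-phenylpropyl with the much smaller 2-aminoethyl gives a 33-fold higher number from compound 2 to compound 4 (1.52 log units; beyond the scatter), a second large step at this amide-type nitrogen and the first to start from compound 2. Yet the new group does not return the number to that of compound 1, as a 5.9-fold lower number from compound 1 to compound 4 (0.77 log units; beyond the scatter) shows, so two groups without a ring still differ beyond the scatter. Among the compounds that differ at this nitrogen, the low number so far goes only with the group carrying the aromatic ring, and the number also moves between the two groups that lack one.

From the compounds shown here alone, what a benzyl group or a longer chain ending in an amine would give here stays open, so the ring and the chain length cannot yet be told apart. Nothing measured here accounts for either step.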